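The source may report more compounds than this note shows. Statements on the series, on what has been measured and on what is new or still open speak of the compounds shown alone.

Working notes on the series. Of the compounds shown here, three have been measured in a functional assay for inhibition, read by spectrophotometry, with a stated time of 20 min, tested at 3 mg/mL (a higher number here means a stronger effect of the compound at the concentration tested, a lower number a weaker effect), so far. Compound 1 `CC(=O)c1ccc(NC(=O)C(C(C)C)N(C(=O)c2ccccc2)S(=O)(=O)c2ccc([N+](=O)[O-])cc2)cc1` gives 29.8% in this assay. Compound 3 `CC(=O)c1ccc(NC(=O)C(C(C)C)N(C(=O)c2ccccc2)S(=O)(=O)c2ccccc2)cc1` gives 47.5% in this assay. The change between them, (hydrogen in place of nitro on an aromatic carbon), gave a number 17.7 percentage points higher from compound 1 to compound 3 (beyond the scatter). Compound 2 `CC(=O)c1ccc(NC(=O)C2CC(O)CN2S(=O)(=O)c2ccc([N+](=O)[O-])cc2)cc1` gives 58.7% in this assay, the highest of the three numbers, with compound 3 nearest and compound 1 furthest, both beyond the scatter. How the core of compound 2 differs from the core of compound 1 is not broken down here.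

Compound 4 `CC(=O)c1ccc(NC(=O)C2CC(O)CN2S(=O)(=O)c2ccccc2)cc1` is still to be measured in this assay. It carries the same change relative to compound 2, (hydrogen in place of nitro on an aromatic carbon), and the place is described in the same words as for the pair of compound 1 and compound 3. For the measured compounds named here, a step of comparable size is expected, a number 11.3 percentage points higher from compound 2 to compound 4 (beyond the scatter), resting on the single earlier step of a number 17.7 percentage points higher from compound 1 to compound 3 (beyond the scatter). Going by the values given here, with only one precedent, on a different core, the expectation is loose. Compound 4 is expected to give about 70% in this assay, within roughly 55% to 85%.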

Compound 4, a percentage reported as inhibition, at one concentration (the size of the read-out at that concentration, not a potency): 49.8%
Compound 4: middle estimate off by 20.2 percentage points, on the high side; the measured number lies below the stated range.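

In this assay, the change from 4-nitrophenyl to phenyl gave a number 8.9 percentage points lower from compound 2 to compound 4 (within the scatter), so the rise seen on the other core did not appear on this one. For the compounds shown here, the change therefore does not carry over as a fixed step between these two cores: the same change on two cores in this assay, a number 17.7 percentage points higher (beyond the scatter) from compound 1 to compound 3 and a number 8.9 percentage points lower (within the scatter) from compound 2 to compound 4, 26.6 percentage points apart, beyond the scatter of two such steps This shows that a step measured on one core is a poor guide to the step on the other, but it does not show a reversal of direction, since the new step lies within the scatter, and it does not show why the two cores differ, with only one pair on each.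

The compounds shown leave open whether another group on that aromatic carbon, such as an amine or a carboxylic acid, would also behave differently on the two cores. They also leave open which of the features that separate the core of compound 1 from the core of compound 2 matters for this difference.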